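Working notes on the shared core: methyl to ethyl step

The source may hold more compounds than are shown below. What is called first, only, known or untested is meant among the compounds shown, and "the series" means these compounds.

The three measured compounds share one core and differ only in the group on a saturated chain carbon bound to an amine nitrogen in a ring. In an assay on isolated protein for displacement of a labelled ligand from Gonadotropin-releasing hormone receptor (Homo sapiens) (on this read-out lower numbers stand for stronger inhibition and higher numbers for weaker inhibition), compound 1 `Cc1ccc(CN2CCN(c3cccc4[nH]c(-c5ccc(C(C)(C)C)cc5)nc34)CC2)o1` gives 705 nM. Compound 2 `Cc1n[nH]c(C)c1CN1CCN(c2cccc3[nH]c(-c4ccc(C(C)(C)C)cc4)nc23)CC1` gives 68 nM in this assay, and compound 3 `Cc1nc(CN2CCN(c3cccc4[nH]c(-c5ccc(C(C)(C)C)cc5)nc34)CC2)cn1C` gives 10 nM in this assay. Compound 3 stands lowest of the three numbers: a 71-fold lower number from compound 1 to compound 3 (1.85 log units; beyond the scatter) and a 6.8-fold lower number from compound 2 to compound 3 (0.83 log units; beyond the scatter) both place it beyond the scatter from the other two, while a 10-fold lower number from compound 1 to compound 2 (1.02 log units; beyond the scatter) covers the remaining pair.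

Compound 4 `CCn1cc(CN2CCN(c3cccc4[nH]c(-c5ccc(C(C)(C)C)cc5)nc34)CC2)nc1C` keeps the core and differs from compound 3 by methyl in place of hydrogen on a saturated chain carbon bound to an aromatic nitrogen; read one bond further out, this is methyl to ethyl, 1,2-dimethyl-1H-imidazol-4-yl to 1-ethyl-2-methyl-1H-imidazol-4-yl. Among the measured compounds shown here, none of the measured steps bears on this change: each of them exchanges the whole heteroaryl group, and no measured pair differs by a single methyl on a saturated chain carbon bound to an aromatic nitrogen. The large steps seen so far therefore give no guide to this smaller change. The expectation is a step within the scatter, a 1.2-fold higher number from compound 3 to compound 4 (0.08 log units; within the scatter), with no firm direction. Compound 4 is accordingly estimated at 12 nM in this assay, with a range from 4 nM to 40 nM.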

Compound 4, half-maximal inhibitory concentration: 10 nM
Compound 4: middle estimate off by 1.2-fold (0.08 log units), on the high side, and the stated range covers the measured number.
By their numbers in this assay, from the lowest: compounds 3 and 4 (each within the scatter of the next); then compound 2; then compound 1.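

In this assay, among the compounds shown here, methyl to ethyl, with methyl in place of hydrogen on a saturated chain carbon bound to an aromatic nitrogen, gives no change at the digits printed from compound 3 to compound 4 (within the scatter), so this is the first measured change that leaves the whole 1,2-dimethyl-1H-imidazol-4-yl group in place, and one added carbon here does not move the number beyond the scatter. The wide gaps to the other heteroaryl groups also carry over to the ethyl analogue, with a 6.8-fold lower number from compound 2 to compound 4 (0.83 log units; beyond the scatter) and a 71-fold lower number from compound 1 to compound 4 (1.85 log units; beyond the scatter), matching the modest and large steps already seen for the methyl compound. No measurement at hand speaks to why the number holds at this position.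

This is a single pair, so it does not show how far the position can be extended: a longer chain such as propyl, or a chain ending in an amine or a carboxylic acid, could behave differently. As far as these compounds go, it also remains open whether the same one-carbon change would be as quiet on a group other than this imidazole, such as the 3,5-dimethyl-1H-pyrazol-4-yl of compound 2.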